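One Bicyclic Arm for Another: Compound 1 to Compound 3

A few compounds are considered here, and "the series" means these few. Any claim that something is new, unique, unknown or untested is made for them only; others in the source may bear on it.

Measured so far in a functional assay on MGC-803 cells (Homo sapiens) for inhibition, read by MTT assay, with a stated time of 72 h; a lower number here means a stronger inhibitor, a higher number a weaker inhibitor:
compound 1 `Cc1cc(Nc2cc(-c3ccccc3)[nH]n2)n2nc(SCc3csc4ccccc34)nc2n1` — 2280 nM
compound 2 `Cc1cc(Nc2cc(-c3cccs3)[nH]n2)n2nc(SCc3ccc(Br)cc3)nc2n1` — 3770 nM

Within the data shown here, only two compounds carry a number in this assay. Compound 1 gives the lower of the two, 2280 nM, while compound 2 gives 3770 nM. The gap between them lies within the scatter of repeated measurements, so the two values show no real difference in potency, and neither compound can be called the stronger one. The two also differ in more than one place, so nothing can be drawn from their comparison about any single structural change.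

Compound 3 `Cc1cc(Nc2cc(-c3ccccc3)[nH]n2)n2nc(SCc3cccc4ccccc34)nc2n1` has not yet been measured. It differs from compound 1 in one place:

naphthalen-1-yl in place of 1-benzothiophen-3-yl on a saturated chain carbon bound to a sulfur

Among the measured compounds shown here, no measured pair isolates this change, so there is no step to lean on. Both groups are bicyclic aromatic arms of similar size, and the estimate is that the step from compound 1 to compound 3 is small, a 1.1-fold higher number from compound 1 to compound 3 (0.04 log units; within the scatter), not beyond the scatter in either direction. Compound 3 is therefore expected to give about 2500 nM in this assay, within a range from 1000 nM to 6500 nM.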

Compound 3, half-maximal inhibitory concentration: 3120 nM
Compound 3: middle estimate off by 1.2-fold (0.10 log units), on the low side, within the range that was stated.
By their numbers in this assay, from the lowest: compounds 1, 3 and 2 (each within the scatter of the next).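

In this assay, among these compounds, putting naphthalen-1-yl in place of 1-benzothiophen-3-yl on a saturated chain carbon bound to a sulfur gives a 1.4-fold higher number from compound 1 to compound 3 (0.14 log units; within the scatter), and this is the first step that isolates a single place. It shows that at this position the five-membered aromatic ring with its sulfur can give way to a second six-membered aromatic ring of carbon only, with hydrogen-bond acceptors going from 1 to 0, and no difference beyond the scatter appears. Nothing available explains why the two arms read alike.

This single step compares only two bicyclic aromatic arms, so it says nothing about how far the position would tolerate a group of another kind, such as a cyclohexyl ring, a morpholine or a carboxylic acid. It also leaves open what a longer chain between the sulfur and the arm would do to the number in this assay.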